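This account rests on a few compounds, and the source may have more. Where it says the series, first, only, none or still open, it means among the compounds named here.

In a functional assay on HCT-116 cells (Homo sapiens), read by MTT assay, with a stated time of 72 h (on this read-out lower numbers stand for stronger inhibition and higher numbers for weaker inhibition), compound 1 `CSc1ncnc2c1c(-c1ccoc1)cn2[C@@H]1O[C@H](CO)[C@@H](O)[C@H]1O` gives 100 nM. Compound 3 `C#Cc1cn([C@@H]2O[C@H](CO)[C@@H](O)[C@H]2O)c2ncnc(SC)c12` gives 90 nM, and the two sit level, with a 1.1-fold lower number from compound 1 to compound 3 (0.05 log units; within the scatter). Compound 2 `CSc1ncnc2c1c(-c1ccccc1)cn2[C@@H]1O[C@H](CO)[C@@H](O)[C@H]1O` gives > 20000 nM, which is a limit of the assay. Measured against that limit, the other two steps are large: an at least 200-fold higher number from compound 1 to compound 2 (2.30 log units; beyond the scatter), and an at least 220-fold lower number from compound 2 to compound 3 (2.34 log units; beyond the scatter).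

Compound 4 `CN(C)c1ncnc2c1c(-c1ccoc1)cn2[C@@H]1O[C@H](CO)[C@@H](O)[C@H]1O` keeps the furan-3-yl group of compound 1 and differs at another place, with dimethylamino in place of methylsulfanyl on an aromatic carbon. Among the measured compounds shown here, none of the measured steps touches this place, since all three exchange furan-3-yl, phenyl or ethynyl on a different aromatic carbon, so they bear on the change only indirectly. What they do show is that one exchange on the shared core can move the number a long way, as in an at least 200-fold higher number from compound 1 to compound 2 (2.30 log units; beyond the scatter), or leave it unmoved, as in the step to compound 3. A rise beyond the scatter in this assay is therefore expected, though one well short of that largest step, and the uncertainty stays wide. The expected step is a 12-fold higher number from compound 1 to compound 4 (1.08 log units; beyond the scatter). For compound 4 the estimated value is 1200 nM, with an expected range from 150 nM to 12000 nM.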

Compound 4, half-maximal inhibitory concentration: > 20000 nM
Compound 4 was reported as a limit; the forecaster's own chance of this, stated with the estimate: 15%; at least 16-fold (1.22 log units) between middle value and limit.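

With the furan-3-yl group held fixed, dimethylamino in place of methylsulfanyl in this assay gives an at least 200-fold higher number from compound 1 to compound 4 (2.30 log units; beyond the scatter). Among the compounds shown here, the earlier steps all lay on a different aromatic carbon, so this is the first sign that the place next to the ring nitrogen also matters, and that one exchange there is enough to take compound 1 out of the measurable range of this assay. Only a lower bound on this step can be read, and its true size stays unknown, since compound 4 ends at a limit rather than at a number: the limit of > 20000 nM in this assay, at which 2 of the 4 values shown sit.

The compounds shown leave open whether any other group at this place would keep the activity of compound 1, for example a smaller amine such as methylamino, an unsubstituted amine or a methoxy group. They also leave open whether dimethylamino would have the same outcome alongside the ethynyl group of compound 3 instead of furan-3-yl.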